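Swapping the anilino ring toward a hydroxyphenyl

A few compounds are considered here, and "the series" means these few. Any claim that something is new, unique, unknown or untested is made for them only; others in the source may bear on it.

Measured so far:
Compound 1, `Fc1cccc(-c2nc(Nc3ccccc3F)c3cc(F)ccc3n2)c1`, in a functional assay on HT29-AK cells (Homo sapiens) for cytotoxicity, read by MTT assay, with a stated time of 48 h (on this read-out higher numbers stand for weaker inhibition and lower numbers for stronger inhibition), reaches only the limit > 50000 nM, not a number.
Compound 2, `Fc1cccc(-c2nc(Nc3ccc(Br)cc3)c3cc(F)ccc3n2)c1`, in this assay reaches only the limit > 50000 nM, likewise not a number.

Compound 2 therefore stands at the limit of this assay, and the only other measurement shown, that of compound 1, sits at the same limit. Going by the values given here, the one step between measured compounds, a step that the two limits leave unreadable from compound 1 to compound 2, cannot be read from the two limits, and the limit of > 50000 nM in this assay, at which 2 of the 2 values shown sit, is the sole evidence on it. Compound 3, `Oc1ccccc1Nc1nc(-c2cccc(F)c2)nc2ccc(F)cc12`, has not yet been measured. It differs from compound 2 by 2-hydroxyphenyl in place of 4-bromophenyl on a nitrogen on an aromatic ring. Among the compounds with values here, no measured step bears on this change, since the exchange of the aryl group on that nitrogen between compound 1 and compound 2 left both at the limit. Compound 3 is thus expected to stay close to the limit, with the step of a number no higher from compound 2 to compound 3 (the limit leaves the size open) expected to be none that can be read. Compound 3 is estimated at 50000 nM, within 10000 nM to 100000 nM, most probably reported again as a limit.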

Compound 3, half-maximal inhibitory concentration: > 50000 nM
Compound 3: no number, only a limit; the forecaster's own chance of this, stated with the estimate: 70%; the middle value sits exactly at the limit.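

In this assay compound 3 gives > 50000 nM, a limit and not a number, so neither its step from compound 1 nor its step from compound 2 can be read: the limit of > 50000 nM in this assay, at which 3 of the 3 values shown sit.

The compounds shown leave open whether any aryl group on that nitrogen would give a measurable value in this assay.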